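The compounds below may be only part of what the source reports. "The series", "measured", "known", "first", "only" and "open" are said of these compounds alone.

Measured compounds:
compound 1 `CC[C@H](C)[C@H](N)CN(C(=O)[C@@H]1C[C@H]1c1ccc(OC)cc1)c1ccc(-c2ccccc2)cc1`: > 25000 nM (a limit)
compound 2 `CC[C@H](C)[C@H](N)CN(C(=O)[C@@H]1C[C@H]1c1nccs1)c1ccc(-c2ccccc2)cc1`: 210 nM

Going by the values given here, in a functional assay for agonist activity at G protein-coupled receptor 88 (Homo sapiens), read by HTRF and cAMP accumulation (on this read-out lower numbers stand for an effect already at smaller amounts and higher numbers for an effect only at larger amounts of compound), compound 2 gives 210 nM, the only actual number. For compound 1 only the limit of > 25000 nM in this assay, at which 1 of the 2 values shown sits, is reported, a limit of the assay and not a number. Among the compounds with values here, the single measured step, an at least 110-fold lower number from compound 1 to compound 2 (2.07 log units; beyond the scatter), is large and came from exchanging 4-methoxyphenyl for 1,3-thiazol-2-yl on the saturated ring carbon.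

Compound 3 `CC[C@H](C)[C@H](N)CN(C(=O)[C@@H]1C[C@H]1c1cccs1)c1ccc(-c2ccccc2)cc1` differs from compound 2 by thiophen-2-yl in place of 1,3-thiazol-2-yl on a saturated ring carbon. Within the data shown here, no measured step covers this exchange; the one known step bears on it only as far as both replacements keep a small aromatic ring on the same carbon. The expected step is therefore a 1.9-fold higher number from compound 2 to compound 3 (0.28 log units; within the scatter), within or near the scatter rather than a change of the size seen before. Compound 3 is estimated at 400 nM, with a range of 100 nM to 2500 nM in this assay.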

Compound 3, half-maximal effective concentration: 360 nM
Estimate against measurement, compound 3: 1.1-fold (0.05 log units) above, and the stated range covers the measured number.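

In this assay the exchange of 1,3-thiazol-2-yl for thiophen-2-yl on the saturated ring carbon gives a 1.7-fold higher number from compound 2 to compound 3 (0.23 log units; within the scatter), so this position tolerates a carbon in place of the ring nitrogen, with one hydrogen-bond acceptor fewer. The step of an at least 69-fold lower number from compound 1 to compound 3 (1.84 log units; beyond the scatter) is large, as was the first step, and now holds for two different five-membered aromatic rings in place of 4-methoxyphenyl, so it is not tied to 1,3-thiazol-2-yl alone. Compound 1 stands as a limit of the assay and not a number, so the full size of both steps from it stays unknown: the limit of > 25000 nM in this assay, at which 1 of the 3 values shown sits.

The compounds shown do not separate the methoxy group of compound 1 from its six-membered ring; a plain phenyl on the same carbon would do so. On these data alone, how an amine or a carboxylic acid on the thiophen-2-yl ring would read also stays open.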